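Aryl swap on the shared core: trifluoromethylphenyl analogue

The source may report more compounds than this note shows. Statements on the series, on what has been measured and on what is new or still open speak of the compounds shown alone.

Compound 2 `Fc1ccccc1-c1cn2ccnc2c(-c2ccc3ncn(C4CCCCC4)c3c2)n1` carries a 2-fluorophenyl group on the shared core; in a functional assay on K562 cells (Homo sapiens) for inhibition, read by sulforhodamine B assay, with a stated time of 48 h, tested at 10 uM (a higher number here means more inhibition at the concentration tested (going by the name of the read-out), a lower number less inhibition), compound 2 gives 22.8%. Among the measured compounds shown here, its only measured neighbour is compound 1 `c1ccc2c(-c3cn4ccnc4c(-c4ccc5ncn(C6CCCCC6)c5c4)n3)cccc2c1`, which in this assay gives 30.9%; the two numbers sit within the scatter of each other, the step being a number 8.1 percentage points lower from compound 1 to compound 2 (within the scatter).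

Compound 3 `FC(F)(F)c1cccc(-c2cn3ccnc3c(-c3ccc4ncn(C5CCCCC5)c4c3)n2)c1` differs from compound 2 in one place: 3-(trifluoromethyl)phenyl in place of 2-fluorophenyl on an aromatic carbon.

For the measured compounds named here, no measured step covers a trifluoromethyl-bearing phenyl ring at this position. Going by the values given here, the one step that touches the same place, a number 8.1 percentage points lower from compound 1 to compound 2 (within the scatter), exchanged one aryl group for another and stayed within the scatter. By analogy, the step from compound 2 to compound 3 is expected to stay within the scatter as well, a number 2.2 percentage points higher from compound 2 to compound 3 (within the scatter). For compound 3 in this assay the estimate is 25%, with a range from 8% to 45%.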

Compound 3, a percentage reported as inhibition, at one concentration (the size of the read-out at that concentration, not a potency): 21.5%
For compound 3 the middle estimate is 3.5 percentage points above the measured one, and the stated range covers the measured number.
By their numbers in this assay, from the lowest: compounds 3, 2 and 1 (each within the scatter of the next).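

In this assay, a third group at this position, 3-(trifluoromethyl)phenyl, stays within the scatter of both earlier groups (a number 1.3 percentage points lower from compound 2 to compound 3 (within the scatter), and a number 9.4 percentage points lower from compound 1 to compound 3 (within the scatter)). The position has now held naphthalen-1-yl, 2-fluorophenyl and 3-(trifluoromethyl)phenyl, and no listed step between these three groups leaves the scatter, so the readings of compound 1, compound 2 and compound 3 do not separate them, even with the change from fluorine to trifluoromethyl on the phenyl ring. No supporting data bear on why the readings stay this close.

Still open, going by these compounds, is whether a phenyl ring carrying an amine or a carboxylic acid, or a longer alkyl chain in place of the aryl group, would move the reading beyond the scatter. The compounds shown also leave open how the rest of the shared core contributes, since all of them vary only at this one place.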